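Replacing an Ester Arm with a Chlorinated Aryl Arm

The source may hold more compounds than are shown below. What is called first, only, known or untested is meant among the compounds shown, and "the series" means these compounds.

Compound 1 `COC(=O)Cc1c(C)[nH]n(-c2nc3ccccc3[nH]2)c1=O` is the weaker of the two measured compounds: in an assay on isolated protein for inhibition of alpha-ketoglutarate-dependent dioxygenase alkB homolog 3 (Homo sapiens), read by polymerase chain reaction, with a stated time of 1 h (on this read-out lower numbers stand for stronger inhibition and higher numbers for weaker inhibition), compound 1 gives 4300 nM, whereas compound 2 `Cc1[nH]n(-c2nc3cc(Br)ccc3[nH]2)c(=O)c1Cc1ccccc1` gives 490 nM, a gap that lies beyond the scatter. Compound 3 `Cc1[nH]n(-c2nc3ccccc3[nH]2)c(=O)c1Cc1ccccc1Cl` is built from compound 1 by the change (2-chlorophenyl in place of methoxycarbonyl on a saturated chain carbon bound to an aromatic carbon). No measured pair isolates this exact change, so any expectation rests on the two numbers shown. Because compound 2 sits at 490 nM, compound 3 is expected to move in the same direction, a step of a 5.4-fold lower number from compound 1 to compound 3 (0.73 log units; beyond the scatter). Compound 3 is estimated at 800 nM, likely between 300 nM and 2500 nM.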

Compound 3, half-maximal inhibitory concentration: > 10000 nM
Compound 3 was reported as a limit; the forecaster's own chance of this, stated with the estimate: 5%; middle value at least 12-fold (1.09 log units) away from the limit.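

In this assay, putting 2-chlorophenyl in place of methoxycarbonyl gives an at least 2.3-fold higher number from compound 1 to compound 3 (0.36 log units; beyond the scatter), so this change at this position moves towards weaker inhibition. On the core of compound 1, the ester arm is the better of the two arms. The reading for compound 3 is a limit and not a number: the limit of > 10000 nM in this assay, at which 1 of the 3 values shown sits.

Compound 2 differs from compound 3 in more than one place, so it leaves open whether the chlorine or the aromatic ring carries the loss. On these data alone, how a carboxylic acid or an amine would read on this chain carbon also remains open.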